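Methoxy in place of chloro: working notes

A few compounds are considered here, and "the series" means these few. Any claim that something is new, unique, unknown or untested is made for them only; others in the source may bear on it.

Of the compounds shown here, three have been read so far in a functional assay on NCI-H522 cells (Homo sapiens) for cytotoxicity, with a stated time of 3 days; a higher number here means a weaker inhibitor, a lower number a stronger inhibitor. Compound 1 `CC#Cc1nc2ccccc2s1` gives > 40000 nM, which is a limit of the assay and not a number. Compound 3 `Ic1nc2ccccc2[se]1` gives > 40000 nM, which is also a limit. Within the data shown here, compound 2 `C#Cc1nc(C(=O)Nc2ccc(Cl)cc2)cs1` gives 540 nM, the only true number in the set, so it is the sole reference point for what follows.

Compound 4 `C#Cc1nc(C(=O)Nc2ccc(OC)cc2)cs1` differs from compound 2 by one change: methoxy in place of chloro on an aromatic carbon. This is methoxy in place of chloro on an aromatic carbon, para to a large group.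

Among the measured compounds shown here, no measured pair in the set shows what this change does in this assay, so the direction is uncertain. A modest weakening is expected, of a size not far beyond the usual scatter, and the range is kept wide. The expected change is a 2.0-fold higher number from compound 2 to compound 4 (0.31 log units; beyond the scatter). Compound 4 is estimated at 1100 nM, with an expected range of 300 nM to 5000 nM.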

Compound 4, half-maximal inhibitory concentration: 670 nM
For compound 4 the middle estimate is 1.6-fold (0.22 log units) above the measured one; the range from low to high includes it.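

Methoxy in place of chloro now has a measured step in this assay, a 1.2-fold higher number from compound 2 to compound 4 (0.09 log units; within the scatter), so this exchange on an aromatic carbon, para to a large group, produces no readable change. The gain of a hydrogen-bond acceptor and the move from one heavy atom to two therefore leave compound 4 not told apart from compound 2 in this read-out. The position accepts either group with a true number retained, which a single reference compound could not show.

From the compounds shown here alone, whether an amine, a carboxylic acid or a longer chain such as butoxy at this position would shift the number remains open. Compound 1 and compound 3 differ from this pair in more than one place and cannot be read against it, and their values are limits of the assay: the limit of > 40000 nM in this assay, at which 2 of the 4 values shown sit.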